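The source may hold more compounds than are shown below. What is called first, only, known or untested is meant among the compounds shown, and "the series" means these compounds.

Compounds measured so far:
- compound 1, `CCC1(Cc2ccccc2)OS(=O)(=O)C=C1OCC#N`: > 400000 nM
- compound 2, `CCC1(Cc2ccccc2)OS(=O)(=O)C=C1OCC1CCCCC1`: >= 200000 nM
- compound 3, `C=CCOC1=CS(=O)(=O)OC1(CC)Cc1ccccc1`: 80000 nM

All three were tested in an ADME assay on HEL cells (Homo sapiens) for cytotoxicity, with a stated time of 3 days; on this read-out higher numbers stand for lower toxicity in this test and lower numbers for higher toxicity in this test. Compound 1 stands only at a limit of this assay, (the limit of > 400000 nM in this assay, at which 1 of the 3 values shown sits), so no number is known for it. Compound 2 also sits at a limit, (the limit of >= 200000 nM in this assay, at which 1 of the 3 values shown sits). Among the compounds with values here, compound 3 is the only one with a number.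

The new compound 4, `CCC1(Cc2ccccc2)OS(=O)(=O)C=C1OCc1ccc(C)cc1`, differs from compound 1 in one place: 4-methylphenyl in place of cyano on a saturated chain carbon bound to an oxygen on an unsaturated carbon.

Two measured steps start from compound 1. The step that the two limits leave unreadable from compound 1 to compound 2 cannot be read, as both ends are limits. The step of an at least 5.0-fold lower number from compound 1 to compound 3 (0.69 log units; beyond the scatter) is a clear drop. The step of an at least 2.5-fold lower number from compound 2 to compound 3 (0.39 log units; beyond the scatter) also points downwards. In every readable case, replacing cyano on that saturated chain carbon with a larger group gave a lower number, so for compound 4 a lower number than compound 1 is expected, roughly an at least 4.0-fold lower number from compound 1 to compound 4 (0.60 log units; beyond the scatter). Compound 4 is therefore estimated at 100000 nM, somewhere between 30000 nM and 400000 nM.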

Compound 4, minimum cytotoxic concentration: >= 16000 nM
Compound 4 was reported as a limit (the forecaster's own chance of this, stated with the estimate: 40%); the middle value is on the limit's open side.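

Compound 4 is reported only as a limit, >= 16000 nM. None of its steps to compound 1, compound 2 or compound 3 can be read. The compounds shown leave open where compound 4 truly lies, and so how 4-methylphenyl in place of cyano shifts the read-out.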